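Methyl to ethyl on the ring amine of compound 3

A few compounds are considered here, and "the series" means these few. Any claim that something is new, unique, unknown or untested is made for them only; others in the source may bear on it.

Of the compounds shown here, three sharing one core have been measured in a functional assay on HT-29 cells (Homo sapiens) for cytotoxicity, read by MTT assay, with a stated time of 24 h, tested at 16 ug/mL; on this read-out higher numbers stand for a stronger effect at the one concentration tested and lower numbers for a weaker effect. Compound 1 `Cn1c(-c2ccc(NC(=O)CSc3nc4ccccc4o3)cc2)nc(-c2ccccc2)c1-c1ccccc1` gives 56.2% in this assay, and compound 2 `Cn1cnnc1SCC(=O)Nc1ccc(-c2nc(-c3ccccc3)c(-c3ccccc3)n2C)cc1` gives 59.1%. Compound 3 `CN1CCN(CC(=O)Nc2ccc(-c3nc(-c4ccccc4)c(-c4ccccc4)n3C)cc2)CC1` gives 33.7% in this assay, the lowest of the three; its gap to compound 1, a number 22.5 percentage points lower from compound 1 to compound 3 (beyond the scatter), and to compound 2, a number 25.4 percentage points lower from compound 2 to compound 3 (beyond the scatter), both lie beyond the scatter, so on these numbers compound 3 is the weakest. The remaining step, a number 2.9 percentage points higher from compound 1 to compound 2 (within the scatter), lies within the scatter.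

Compound 4 `CCN1CCN(CC(=O)Nc2ccc(-c3nc(-c4ccccc4)c(-c4ccccc4)n3C)cc2)CC1` differs from compound 3 by methyl in place of hydrogen on a saturated chain carbon bound to an amine nitrogen in a ring. Among the compounds with values here, none of the measured steps bears directly on this kind of change: the two steps that reach compound 3 each replace a whole sulfanyl heterocycle with the 4-methylpiperazin-1-yl group, and the step between compound 1 and compound 2 exchanges one heterocycle for another on a sulfur. A single added carbon on a saturated chain carbon bound to an amine nitrogen in a ring is a much smaller alteration than any of these, so no step beyond the scatter is expected, in either direction, giving an estimated a number 1.3 percentage points higher from compound 3 to compound 4 (within the scatter). Compound 4 is therefore expected to give about 35% in this assay, within a range from 24% to 46%.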

Compound 4, a percentage reported as activity, at one concentration (the size of the read-out at that concentration, not a potency): 28.4%
The estimate for compound 4 lay 6.6 percentage points above the measured number; the range from low to high includes it.
By their numbers in this assay, from the lowest: compounds 4 and 3 (each within the scatter of the next); then compounds 1 and 2 (each within the scatter of the next).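

Methyl to ethyl on the ring amine gives, in this assay, a number 5.3 percentage points lower from compound 3 to compound 4 (within the scatter), so this first direct reading at the position shows that changing 4-methylpiperazin-1-yl to 4-ethylpiperazin-1-yl keeps the result within the scatter. The gap to the sulfanyl compounds also holds with the ethyl group in place, with a number 30.7 percentage points lower from compound 2 to compound 4 (beyond the scatter) and a number 27.8 percentage points lower from compound 1 to compound 4 (beyond the scatter), so the separation first seen with compound 3 is now seen with a second amine of this kind. No measured evidence here speaks to the cause of these results.

On these data alone, whether a longer chain such as propyl, a benzyl group or a bare hydrogen on the ring amine would also stay within the scatter of compound 3 remains open, since one added carbon samples very little of what this position could carry. Also open, as far as these compounds go, is whether the gap to the sulfanyl compounds depends on the piperazin-1-yl group as such, a question that a morpholin-4-yl or dimethylamino group on the saturated chain carbon bound to a carbonyl carbon could help to answer.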